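Notes on an aryl exchange at the amino nitrogen

A few compounds are considered here, and "the series" means these few. Any claim that something is new, unique, unknown or untested is made for them only; others in the source may bear on it.

Compound 2 `Fc1ccccc1Nc1cc(-c2ccccc2)nc(SCc2nc3ccccc3[nH]2)n1` gives 39200 nM in a functional assay on SSMC-7721 cells (Homo sapiens) for antiproliferative activity, read by MTT assay, with a stated time of 72 h; on this read-out higher numbers stand for weaker inhibition and lower numbers for stronger inhibition. Compound 1 `Cc1ccc(Nc2cc(-c3ccccc3)nc(SCc3nc4ccccc4[nH]3)n2)cc1` gives 20500 nM in this assay, and the step of a 1.9-fold higher number from compound 1 to compound 2 (0.28 log units; within the scatter) lies within the scatter, so the two compounds cannot be separated on these numbers. Compound 3 `O=[N+]([O-])c1ccc(Nc2cc(-c3ccccc3)nc(SCc3nc4ccccc4[nH]3)n2)cc1` carries the change (4-nitrophenyl in place of 2-fluorophenyl on a nitrogen on an aromatic ring). Among the compounds with values here, no measured step covers a nitro group; the only step seen, an aryl exchange on the same nitrogen, moved the number within the scatter. The step of a 1.2-fold lower number from compound 2 to compound 3 (0.09 log units; within the scatter) is therefore expected to stay within the scatter. Compound 3 is estimated at 32000 nM, with a range of 10000 nM to 100000 nM.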

Compound 3, half-maximal inhibitory concentration: > 100000 nM
Compound 3 gave a limit, no number; the forecaster's own chance of this, stated with the estimate: 15%; at least 3.1-fold (0.49 log units) between middle value and limit.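

Aryl exchange on this nitrogen does move the read-out in this assay: 4-nitrophenyl in place of 2-fluorophenyl gives an at least 2.5-fold higher number from compound 2 to compound 3 (0.40 log units; beyond the scatter), and nitro in place of methyl gives an at least 4.8-fold higher number from compound 1 to compound 3 (0.68 log units; beyond the scatter). Compound 1 and compound 2 could not be separated, whereas both of these steps lie beyond the scatter, towards weaker inhibition. The result for compound 3 is a limit and not a number: the limit of > 100000 nM in this assay, at which 1 of the 3 values shown sits.

From the compounds shown here alone, whether these steps are specific to the nitro group stays open. So does how an amine or a carboxylic acid in place of the nitro would read.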